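Aryl piperazine variation on the oxazole series

The compounds below may be only part of what the source reports. "The series", "measured", "known", "first", "only" and "open" are said of these compounds alone.

Measured so far:
compound 1, `CCCc1nc(-c2ccccc2)c(CNCCCN2CCN(c3ccc(C(F)(F)F)cc3)CC2)o1`: 51.6%
compound 2, `CCCc1nc(-c2ccccc2)c(CNCCN2CCN(c3cccc(Cl)c3)CC2)o1`: 51.2%

In an assay on HEK293 cells for inhibition of Voltage-dependent T-type calcium channel subunit alpha-1G (Homo sapiens), read by fluorescence, tested at 10 uM (on this read-out lower numbers stand for less inhibition and higher numbers for more inhibition at the one concentration tested (going by the name of the read-out)), compound 1 gives 51.6% and stands highest of the two numbers, though compound 2, with 51.2%, sits within the scatter of it, so the two cannot be told apart on this read-out. Among the measured compounds shown here, no step between two measured compounds that differ in a single place is available, so there is no measured guide to how a change at the aryl group on the ring nitrogen moves this assay.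

Compound 3, `CCCc1nc(-c2ccccc2)c(CNCCCN2CCN(c3ccccc3C)CC2)o1`, is not yet measured. It differs from compound 1 in one place: 2-methylphenyl in place of 4-(trifluoromethyl)phenyl on an amine nitrogen in a ring. For the measured compounds named here, with no single-place step to lean on, the expectation rests only on the two measured values, which show that two different aryl groups on that ring nitrogen, combined with different chain lengths, both land near the middle of the scale in this assay.

For compound 3 the expected step of a number 6.6 percentage points lower from compound 1 to compound 3 (within the scatter) is small and downward, but not clearly beyond the scatter. Compound 3 is estimated at 45%, with a range from 25% to 65%.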

Compound 3, a percentage reported as inhibition, at one concentration (the size of the read-out at that concentration, not a potency): 54.5%
Beside the measured number, compound 3's estimate is 9.5 percentage points below it; measured number inside the range.
By their numbers in this assay, from the lowest: compounds 2, 1 and 3 (each within the scatter of the next).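

In this assay, among the compounds shown here, 2-methylphenyl in place of 4-(trifluoromethyl)phenyl on the amine nitrogen in the ring gives the first single-place step for this series, a number 2.9 percentage points higher from compound 1 to compound 3 (within the scatter). This exchange goes from a group of 10 heavy atoms with three fluorine to one of 7 heavy atoms with none, and the substituent moves on the phenyl ring as well, yet the two compounds cannot be told apart on this read-out, so for this pair the change of aryl group does not register beyond the scatter. No measurement bearing on the reason for this outcome is available.

The compounds shown leave open whether anything other than a substituted phenyl on that ring nitrogen, such as a pyridine ring or a benzyl group, or a phenyl carrying an amine or a carboxylic acid, would move the read-out beyond the scatter. Compound 2 differs from compound 1 and from compound 3 in more than one place, so the contribution of chain length cannot be read apart from that of the aryl group, and a longer chain remains an open case.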